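Adding Dimethylamino to Compound 3

A few compounds are considered here, and "the series" means these few. Any claim that something is new, unique, unknown or untested is made for them only; others in the source may bear on it.

In a functional assay on HL-60 cells (Homo sapiens) for cytotoxicity, with a stated time of 24 h (on this read-out lower numbers stand for higher toxicity in this test and higher numbers for lower toxicity in this test), compound 1 `O=C1/C(=C/c2ccc(F)cc2)CCC/C1=C\c1ccccc1[N+](=O)[O-]` gives 3000 nM, and compound 2 `CN(C)c1ccc(/C=C2\CCC/C(=C\c3cccc([N+](=O)[O-])c3)C2=O)cc1` gives 30000 nM. Compound 3 `O=C1/C(=C/c2ccccc2)CCC/C1=C\c1ccc([N+](=O)[O-])cc1` gives 20000 nM, which lies within the scatter of compound 2 and beyond the scatter above compound 1. Compound 4 `CN(C)c1ccc(/C=C2\CCC/C(=C\c3ccc([N+](=O)[O-])cc3)C2=O)cc1` is compound 3 with dimethylamino in place of hydrogen on an aromatic carbon, para to a large group: dimethylamino in place of hydrogen on an aromatic carbon. Within the data shown here, no measured pair isolates this change. Compound 2 already carries dimethylamino and reads 30000 nM, so no step beyond the scatter is expected in this assay. The step expected is no change at the digits printed from compound 3 to compound 4 (within the scatter). Compound 4 is estimated at 20000 nM, with an expected range of 6000 nM to 60000 nM.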

Compound 4, half-maximal cytotoxic concentration: > 400000 nM
Compound 4: no number, only a limit (the forecaster's own chance of this, stated with the estimate: 10%); middle value at least 20-fold (1.30 log units) away from the limit.
By their numbers in this assay, from the lowest: compound 1; then compounds 3 and 2 (each within the scatter of the next). At a limit, above all of these: compound 4.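

Compound 4 stands at a limit of the assay, not at a number: the limit of > 400000 nM in this assay, at which 1 of the 4 values shown sits. On the aromatic carbon para to a large group, dimethylamino brings an at least 20-fold higher number from compound 3 to compound 4 (1.30 log units; beyond the scatter). Dimethylamino alone does not set this reading, since with that group kept, 4-nitrophenyl in place of 3-nitrophenyl brings an at least 13-fold higher number from compound 2 to compound 4 (1.12 log units; beyond the scatter). The compounds shown leave open what an amino group, a methoxy group or a carboxylic acid would give in this place in this assay. They also leave open how far past its limit compound 4 lies.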